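The compounds below may be only part of what the source reports. "The series", "measured", "known", "first", "only" and "open" are said of these compounds alone.

Compound 1 `CS(=O)(=O)NC1CCC(CN2CCN(c3cc(=O)c4cc(C(F)(F)F)cc([N+](=O)[O-])c4s3)CC2)CC1` carries a methanesulfonamido group on a saturated ring carbon. In an ADME assay on Vero cells (Chlorocebus sabaeus) for cytotoxicity, read by MTT assay, with a stated time of 48 h (on this read-out higher numbers stand for weaker inhibition and lower numbers for stronger inhibition), compound 1 gives 48.5 ug/mL, the higher of the two plain numbers shown. Compound 2 `O=C(NC1CCC(CN2CCN(c3cc(=O)c4cc(C(F)(F)F)cc([N+](=O)[O-])c4s3)CC2)CC1)c1ccccc1` is its nearest neighbour, with the benzoyl in place of methylsulfonyl on an amine nitrogen; in this assay compound 2 gives 44.3 ug/mL, so that a 1.1-fold lower number from compound 1 to compound 2 (0.04 log units; within the scatter). Compound 3 `O=C(OC1CCC(CN2CCN(c3cc(=O)c4cc(C(F)(F)F)cc([N+](=O)[O-])c4s3)CC2)CC1)C1CCCCC1` bears a (cyclohexylcarbonyl)oxy group on the same saturated ring carbon. For compound 3 this assay reports only a limit, > 64 ug/mL, because the number lies at the limit of > 64 ug/mL in this assay, at which 1 of the 3 values shown sits.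

Compound 4 `COc1ccc(C(=O)OC2CCC(CN3CCN(c4cc(=O)c5cc(C(F)(F)F)cc([N+](=O)[O-])c5s4)CC3)CC2)cc1` differs from compound 1 in one place: ((4-methoxyphenyl)carbonyl)oxy in place of methanesulfonamido on a saturated ring carbon. Among the measured compounds shown here, the steps that bear on it are the two that put an ester in that position: an at least 1.3-fold higher number from compound 1 to compound 3 (0.12 log units; that floor lies within the scatter) and an at least 1.4-fold higher number from compound 2 to compound 3 (0.15 log units; that floor lies within the scatter). Both of those left only a limit, so one expects compound 4 to sit at or near the limit as well, with no step beyond the scatter from compound 1 that could be measured. Compound 4 is therefore estimated at 60 ug/mL, within 35 ug/mL to 110 ug/mL. The step expected is a 1.2-fold higher number from compound 1 to compound 4 (0.09 log units; within the scatter).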

Compound 4, half-maximal inhibitory concentration: > 64 ug/mL
Compound 4: no number, only a limit; the forecaster's own chance of this, stated with the estimate: 55%; middle value at least 1.0-fold (0.02 log units) away from the limit.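

In this assay compound 4 gives only a limit, > 64 ug/mL, so an ester with an aromatic ring in its acyl part ends at a limit on the saturated ring carbon, just as the cyclohexyl ester of compound 3 does: the limit of > 64 ug/mL in this assay, at which 2 of the 4 values shown sit. Against the two amide-linked groups the result gives an at least 1.3-fold higher number from compound 1 to compound 4 (0.12 log units; that floor lies within the scatter) and an at least 1.4-fold higher number from compound 2 to compound 4 (0.15 log units; that floor lies within the scatter), so neither ester is yet shown to move the number beyond the scatter. The step between compound 3 and compound 4 cannot be read, with a limit on each side.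

The compounds shown leave open how far past the limit either ester lies and whether 4-methoxyphenyl and cyclohexyl differ at all. Also open, on these data alone, is how a free hydroxyl, a primary amine or a carboxylic acid on that saturated ring carbon would read in this assay.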